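The source may report more compounds than this note shows. Statements on the series, on what has been measured and on what is new or still open speak of the compounds shown alone.

Working notes on the series. In an assay on U2OS cells for inhibition of secreted frizzled-related protein 1 (Homo sapiens), read by a luciferase reporter, with a stated time of 18 h (on this read-out higher numbers stand for an effect only at larger amounts of compound and lower numbers for an effect already at smaller amounts), compound 1 `O=C(c1ccc(Cl)nc1)N1CCC(NS(=O)(=O)c2cc(S(=O)(=O)c3ccccc3)ccc2C(F)(F)F)CC1` gives 140 nM. Compound 2 `O=C(CC1CCNCC1)N1CCC(NS(=O)(=O)c2cc(S(=O)(=O)c3ccccc3)ccc2C(F)(F)F)CC1` gives 210 nM in this assay; the two numbers lie within the scatter of each other, the step being a 1.5-fold higher number from compound 1 to compound 2 (0.18 log units; within the scatter). Compound 3 `O=C([C@H]1CCNC1)N1CCC(NS(=O)(=O)c2cc(S(=O)(=O)c3ccccc3)ccc2C(F)(F)F)CC1` differs from compound 2 by pyrrolidin-3-yl in place of (piperidin-4-yl)methyl on a carbonyl carbon. Among the compounds with values here, the single measured step on that carbonyl carbon left the read-out essentially unchanged, and no measured step addresses a change of ring size there. Compound 3 is therefore expected to stay near compound 2, with a 1.2-fold higher number from compound 2 to compound 3 (0.08 log units; within the scatter) as the expected step. The estimate for compound 3 in this assay is 250 nM, ranging from 100 nM to 650 nM.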

Compound 3, half-maximal effective concentration: 700 nM
For compound 3 the middle estimate is 2.8-fold (0.45 log units) below the measured one; the measured number lies above the stated range.
By their numbers in this assay, from the lowest: compounds 1 and 2 (each within the scatter of the next); then compound 3.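

In this assay, within the data shown here, the group on this carbonyl carbon proves able to shift the read-out: pyrrolidin-3-yl in place of (piperidin-4-yl)methyl gives a 3.3-fold higher number from compound 2 to compound 3 (0.52 log units; beyond the scatter) and is the first step beyond the scatter. The same group in place of 6-chloropyridin-3-yl gives a 5.0-fold higher number from compound 1 to compound 3 (0.70 log units; beyond the scatter) and is also beyond the scatter. No supporting data explain this shift.

This change alters ring size and the link to the carbonyl carbon together, leaving their separate contributions open. Piperidin-4-yl attached directly to that carbon would separate them, while the opposite stereoisomer of pyrrolidin-3-yl remains an open comparison.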